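The source may report more compounds than this note shows. Statements on the series, on what has been measured and on what is new or still open speak of the compounds shown alone.

Two compounds of the series carry numbers in a functional assay on SF-539 cells (Homo sapiens) for inhibition, read by sulforhodamine B assay, with a stated time of 48 h; on this read-out higher numbers stand for weaker inhibition of growth and lower numbers for stronger inhibition of growth. Compound 1 `N=C(N)c1ccc(-c2ccc(-c3cncc4ccccc34)s2)s1` gives 1730 nM. Compound 2 `N=C(N)c1ccc(-c2ccc(-c3ccc(F)cc3)o2)o1` gives 1630 nM and stands at the low end of the two numbers, though compound 1 sits within the scatter of it, so the pair cannot be told apart. Compound 3 `N=C(N)c1ccc(-c2ccc(-c3ccc(Cl)cc3)o2)o1` differs from compound 2 by chloro in place of fluoro on an aromatic carbon. Among the measured compounds shown here, no measured pair shows this change, so the expected step of a 1.4-fold lower number from compound 2 to compound 3 (0.13 log units; within the scatter) is small, toward a lower number, hardly beyond the scatter. Compound 3 is estimated at 1200 nM, with a range of 500 nM to 3000 nM.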

Compound 3, concentration for 50% growth inhibition: 1710 nM
For compound 3 the middle estimate is 1.4-fold (0.15 log units) below the measured one; measured number inside the range.
By their numbers in this assay, from the lowest: compounds 2, 3 and 1 (each within the scatter of the next).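

In this assay, among the compounds shown here, chloro in place of fluoro on an aromatic carbon, para to a large group, gives a 1.0-fold higher number from compound 2 to compound 3 (0.02 log units; within the scatter) and provides the first measured single-change pair. At this position, the two halogens cannot be told apart on this read-out. No available data bear on why the exchange leaves the number within the scatter.

On these data alone, whether an amine, a methoxy group or a carboxylic acid at this position would shift growth inhibition remains open. So does whether the parity between chloro and fluoro holds on another core.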